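The source may report more compounds than this note shows. Statements on the series, on what has been measured and on what is new or still open speak of the compounds shown alone.

Among the compounds with values here, compound 2 `Cc1cc(NC(=O)Cn2nnc(-c3ccnc(F)c3)n2)n(C2CCCCC2)n1` is one of two compounds measured in an assay on HEK293 cells for activation of Kir3.1/Kir3.2 (Homo sapiens), read by thallium flux (a higher number here means a larger maximal response, a lower number a smaller maximal response), and compound 2 gives 95%. Its companion compound 1 `Cc1cc(NC(=O)Cn2nnc(-c3ccccc3)n2)n(C2CCCCC2)n1` gives 92% in this assay, so the two stand alongside each other within the scatter. Within the data shown here, the one measured step, a number 3 percentage points higher from compound 1 to compound 2 (within the scatter), came with 2-fluoropyridin-4-yl in place of phenyl on an aromatic carbon and did not move the maximal response beyond the scatter. Compound 3 `Cc1ccc(-c2nnn(CC(=O)Nc3cc(C)nn3C3CCCCC3)n2)cc1` has not yet been measured in this assay. It differs from compound 2 by 4-methylphenyl in place of 2-fluoropyridin-4-yl on an aromatic carbon. This change sits at the same aromatic carbon that the measured step concerned, and that step was small, so a step within the scatter is expected in this assay for compound 3. The estimated step is a number 3 percentage points lower from compound 2 to compound 3 (within the scatter), and compound 3 is expected to give about 92%, between 80% and 104%.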

Compound 3, largest response reached (Emax), in percent of the reference or control that the assay uses: 86%
Compound 3: middle estimate off by 6 percentage points, on the high side; low and high end bracket the measured number.
By their numbers in this assay, from the lowest: compounds 3, 1 and 2 (each within the scatter of the next).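

With compound 3, the aromatic group at this carbon now carries a substituent with no ring nitrogen or fluorine, and this assay still shows no step beyond the scatter: the exchange of 2-fluoropyridin-4-yl for 4-methylphenyl gives a number 9 percentage points lower from compound 2 to compound 3 (within the scatter). Methyl in place of hydrogen on the aromatic carbon of the phenyl group gives a number 6 percentage points lower from compound 1 to compound 3 (within the scatter), so this small addition also leaves the maximal response within the scatter. No measurement shown here offers an explanation for these results.

The compounds shown leave open whether the maximal response would hold with an amine or a carboxylic acid on this aromatic ring, or with a saturated ring such as cyclohexyl in its place. They also leave open how the shared core responds to change elsewhere, since all three keep the same remaining structure.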